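Removing the carboxymethyl group from a plasma-stable biaryl amide

A few compounds are considered here, and "the series" means these few. Any claim that something is new, unique, unknown or untested is made for them only; others in the source may bear on it.

In an ADME assay on a cell-free system (plasma, Homo sapiens) for metabolic stability, read by LC-MS (on this read-out lower numbers stand for a shorter-lived compound and higher numbers for a longer-lived compound), compound 1 `NCc1ccc(C(=O)Nc2ccncc2F)cc1-c1cccc(C(=O)Nc2ccc(CC(=O)O)cc2)c1` reaches the upper limit of the assay, reported as > 2 h, and the figure is a limit rather than a number. Two companions were measured alongside it. Compound 2 `COCCOC(=O)c1ccc(F)c(C(=O)Nc2cccc(-c3cc(C(=O)Nc4ccncc4F)ccc3CN)c2)c1` gives a reading at the lower limit of the assay, < 0.0834 h, again a limit and not a number. Compound 3 `CCCOC(=O)c1cccc(C(=O)Nc2cccc(-c3cc(C(=O)Nc4ccncc4F)ccc3CN)c2)c1` likewise sits at the lower limit, < 0.0834 h. Compound 1 thus stands apart from both companions on the readings shown, at the long-lived end: the limit of > 2 h in this assay, at which 1 of the 3 values shown sits, whereas (the limit of < 0.0834 h in this assay, at which 2 of the 3 values shown sit).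

Compound 4 `NCc1ccc(C(=O)Nc2ccncc2F)cc1-c1cccc(C(=O)Nc2ccccc2)c1` has not yet been measured in this assay. It differs from compound 1 in one place (hydrogen in place of carboxymethyl on an aromatic carbon). Within the data shown here, since the companions differ from compound 1 in more than one place, no single step between measured compounds is available to guide the expectation. The step from compound 1 to compound 4 is therefore expected to be small, within the usual scatter, with a step that the limit leaves unreadable from compound 1 to compound 4. On that basis compound 4 is estimated to give 3 h in this assay, between 1 h and 10 h, most likely reported again as a limit.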

Compound 4, half-life: > 2 h
Compound 4 gave a limit, no number; the forecaster's own chance of this, stated with the estimate: 75%; the middle value is on the limit's open side.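

Among these compounds, compound 1 and compound 4 are both reported only as limits in this assay, so no step between them can be read. The compounds shown leave open whether hydrogen in place of carboxymethyl changes the half-life at all, and in which direction.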